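This account rests on a few compounds, and the source may have more. Where it says the series, first, only, none or still open, it means among the compounds named here.

In a physicochemical assay for solubility, in phosphate buffer, at pH 7.4 (a higher number here means a more soluble compound, a lower number a less soluble compound), compound 1 `CC(=O)N[C@@H]1CCC[C@H](C(=O)Nc2cc(-c3cnn4c3CCCC4)c(Cl)cn2)C1` gives 310000 nM and compound 2 `CC(=O)N[C@@H]1CCC[C@H](C(=O)Nc2cc(-c3cnc4n3CCCC4)c(Cl)cn2)C1` gives 600000 nM, two values within the usual scatter of each other. Compound 3 `CC(=O)N[C@@H]1CCC[C@H](C(=O)Nc2cc(-c3cnc(C)n3C)c(Cl)cn2)C1` gives > 1000000 nM, which is a limit of the assay and not a number.

Compound 4 `CC(=O)N[C@@H]1CCC[C@H](C(=O)Nc2cc(-c3cnc4ccccn34)c(Cl)cn2)C1` keeps the shared core and changes one group: a group of 9 heavy atoms (7 carbon, 2 nitrogen; one five-membered aromatic ring with 2 hetero atoms, one six-membered aromatic ring with 1 hetero atom) in place of a group of 7 heavy atoms (5 carbon, 2 nitrogen; one five-membered aromatic ring with 2 hetero atoms), on an aromatic carbon. Like compounds 1 and 2, it carries a group with two rings, but its six-membered ring is aromatic rather than non-aromatic. The nearest guides run in the opposite direction, since each replaces a two-ring group with 1,2-dimethyl-1H-imidazol-5-yl: an at least 3.2-fold higher number from compound 1 to compound 3 (0.50 log units; beyond the scatter), and an at least 1.6-fold higher number from compound 2 to compound 3 (0.22 log units; that floor lies within the scatter). Read in reverse, these steps point to a lower number in this assay for the new two-ring group. No aromatic second ring has been measured in this set, so the range stays wide. The expected change is an at least 3.3-fold lower number from compound 3 to compound 4 (0.52 log units; beyond the scatter). For compound 4, the estimate is 300000 nM, within an expected range of 100000 nM to 800000 nM.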

Compound 4, solubility: 120000 nM
Beside the measured number, compound 4's estimate is 2.5-fold (0.40 log units) above it, within the range that was stated.
By their numbers in this assay, from the lowest: compound 4; then compounds 1 and 2 (each within the scatter of the next). At a limit, above all of these: compound 3.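

In this assay, compound 4 is the only one shown with an aromatic second ring at this position, opposite the ring nitrogen, and it reads lower than both compounds with a non-aromatic second ring: a 5.0-fold lower number from compound 2 to compound 4 (0.70 log units; beyond the scatter), and a 2.6-fold lower number from compound 1 to compound 4 (0.41 log units; beyond the scatter). All three groups have 9 heavy atoms, so the count of heavy atoms alone does not separate these values. The third step, an at least 8.3-fold lower number from compound 3 to compound 4 (0.92 log units; beyond the scatter), gives a floor and not an exact size, as one end of it is a limit of the assay: the limit of > 1000000 nM in this assay, at which 1 of the 4 values shown sits.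

With a single aromatic two-ring group shown, it stays open whether the lower number goes with aromatic second rings in general or with this group alone. Also open, going by these compounds, is how an amine or a carboxylic acid on that second ring would read in this assay.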